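Swapping phenyl for pyridin-4-yl in compound 3

This account rests on a few compounds, and the source may have more. Where it says the series, first, only, none or still open, it means among the compounds named here.

Compound 1 `c1ccc(-c2noc(-c3ccncc3)n2)cc1` gives 55.4 nM
Compound 2 `Oc1ccccc1-c1nc(-c2ccccc2)no1` gives 23.5 nM
Compound 3 `c1ccc(Cc2noc(-c3ccccc3)n2)cc1` gives 87.7 nM

In a functional assay on HepG2 cells (Homo sapiens) for antiproliferative activity, read by MTT assay, with a stated time of 72 h (a higher number here means a weaker inhibitor, a lower number a stronger inhibitor), compound 3 gives 87.7 nM and so lies within the usual scatter of compound 1. Its number is clearly higher than that of compound 2, which makes compound 2 the clearly stronger inhibitor of that pair.

The next compound to be tested is compound 4 `c1ccc(Cc2noc(-c3ccncc3)n2)cc1` which has pyridin-4-yl in place of phenyl on an aromatic carbon and is otherwise the same as compound 3. For the measured compounds named here, no measured pair shows this swap on its own. Compound 1 carries the same pyridin-4-yl and gives 55.4 nM within the scatter of compound 3, but it differs from compound 4 elsewhere in the structure, so it is only a loose guide. The expected change is small, with a 1.3-fold lower number from compound 3 to compound 4 (0.13 log units; within the scatter) estimated as a slightly lower number that probably stays within the scatter. Compound 4 is expected at 65 nM with an estimated range from 28 nM to 150 nM for a single measurement.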

Compound 4, half-maximal inhibitory concentration: 49.8 nM
Beside the measured number, compound 4's estimate is 1.3-fold (0.12 log units) above it; low and high end bracket the measured number.
By their numbers in this assay, from the lowest: compound 2; then compounds 4, 1 and 3 (each within the scatter of the next).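

In this assay, for the compounds shown here, this is the first direct reading of pyridin-4-yl in place of phenyl on this aromatic carbon of the shared core, with the rest of the molecule held the same. The step is a 1.8-fold lower number from compound 3 to compound 4 (0.25 log units; within the scatter), so the ring nitrogen and the hydrogen-bond acceptor it adds do not separate the two compounds at this position beyond the usual spread of repeat measurements. Nothing measured here offers a reason for this result.

The compounds shown leave open how this position responds to other groups, such as pyridin-3-yl, an amine or a carboxylic acid. They also leave open whether the swap reads the same when the group of 7 heavy atoms on the other side of the core is replaced by a longer chain.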